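Pyrrolidine Amide Replaces Benzylamide in an Edema Series

The source may report more compounds than this note shows. Statements on the series, on what has been measured and on what is new or still open speak of the compounds shown alone.

Measured compounds:
compound 1 `COc1cc2c(cc1OC)C(CC(=O)O)CC2` — 18.8%
compound 2 `CCN(CC)C(=O)CC1CCc2cc(OC)c(OC)cc21` — 31.3%
compound 3 `COc1cc2c(cc1OC)C(CC(=O)NCc1ccccc1)CC2` — 18.8%

Among the measured compounds shown here, in a functional assay on the whole organism (strain Wistar) for inhibition, with Rattus norvegicus as the target, read by paw edema, with stated times of 60 min and 1 h, at a dose of 100 mg/kg by the oral route (on this read-out higher numbers stand for more inhibition at the one dose given (going by the name of the read-out) and lower numbers for less inhibition), compound 3 gives 18.8%, level with compound 1 and together with it the lowest of the three numbers; the only step beyond the scatter is a number 12.5 percentage points lower from compound 2 to compound 3 (beyond the scatter), while no change at the digits printed from compound 1 to compound 3 (within the scatter). Compound 4 `COc1cc2c(cc1OC)C(CC(=O)N1CCCC1)CC2` differs from compound 3 by pyrrolidin-1-yl in place of benzylamino on a carbonyl carbon. The step that bears on this change is a number 12.5 percentage points lower from compound 2 to compound 3 (beyond the scatter): there the group without a hydrogen-bond donor, diethylamino, gave the higher number, and pyrrolidin-1-yl likewise brings no hydrogen-bond donor. For the measured compounds named here, a modest rise is therefore expected, a number 8.2 percentage points higher from compound 3 to compound 4 (within the scatter); no pyrrolidin-1-yl compound has been measured, and the expected rise is kept smaller than that step. Compound 4 is estimated at 27%, within 15% to 40%.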

Compound 4, a percentage reported as inhibition, in the whole organism at one dose (the size of the read-out at that dose, not a potency): 4.69%
Compound 4: middle estimate off by 22.3 percentage points, on the high side; the whole stated range lies above it.
By their numbers in this assay, from the lowest: compound 4; then compounds 1 and 3 (each within the scatter of the next); then compound 2.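

Having no hydrogen-bond donor does not by itself bring the higher number on this carbonyl carbon: pyrrolidin-1-yl falls below benzylamino (a number 14.1 percentage points lower from compound 3 to compound 4 (beyond the scatter)) and well below diethylamino (a number 26.6 percentage points lower from compound 2 to compound 4 (beyond the scatter)), although neither pyrrolidin-1-yl nor diethylamino has one. It also falls below hydroxy (a number 14.1 percentage points lower from compound 1 to compound 4 (beyond the scatter)), so among these compounds, an amide here can stand above or below the acid. As far as these compounds go, whether dimethylamino, piperidin-1-yl or morpholin-4-yl on this carbonyl carbon would follow diethylamino or pyrrolidin-1-yl remains open. Nothing measured here accounts for these differences.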